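The source may hold more compounds than are shown below. What is called first, only, known or untested is meant among the compounds shown, and "the series" means these compounds.

Values in a functional assay on HL-60 cells (Homo sapiens) for cytotoxicity, read by WST assay, with a stated time of 48 h; on this read-out higher numbers stand for an effect only at larger amounts of compound and lower numbers for an effect already at smaller amounts:
- compound 1 `O=C1OC[C@H](Cc2ccccc2)[C@H]1Cc1ccc(Cl)cc1`: 36000 nM
- compound 2 `Oc1ccccc1C[C@H]1COC[C@@H]1Cc1ccc(Cl)c(Cl)c1`: 34000 nM
- compound 3 `CCOc1ccccc1C[C@H]1COC[C@@H]1Cc1ccc(Cl)c(Cl)c1`: 29000 nM

Compound 2 lies within the scatter of both other compounds, so the three numbers cannot be ordered. The change to compound 4 `Fc1cccc(C[C@H]2COC[C@@H]2Cc2ccc(Cl)c(Cl)c2)c1` is 3-fluorophenyl in place of 2-hydroxyphenyl on a saturated chain carbon bound to a saturated ring carbon.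

Among the measured compounds shown here, only one measured step bears on this, a 1.2-fold lower number from compound 2 to compound 3 (0.07 log units; within the scatter). For the measured compounds named here, it alters the oxygen of the group that leaves here, but no measured step removes that oxygen or brings in fluorine, so the support is thin. No step beyond the scatter is expected in this assay, and no direction can be assigned.

The expected result is a 1.1-fold lower number from compound 2 to compound 4 (0.05 log units; within the scatter).

Compound 4 is estimated at 30000 nM, with an expected range of 14000 nM to 65000 nM.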

Compound 4, half-maximal effective concentration: 20000 nM
The estimate for compound 4 lay 1.5-fold (0.18 log units) above the measured number, and the stated range covers the measured number.
By their numbers in this assay, from the lowest: compounds 4, 3, 2 and 1 (each within the scatter of the next).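

In this assay, a 1.7-fold lower number from compound 2 to compound 4 (0.23 log units; within the scatter) is the outcome of replacing 2-hydroxyphenyl with 3-fluorophenyl on a saturated chain carbon bound to a saturated ring carbon. Compound 3 kept the oxygen, whereas compound 4 has none on this group, and its hydrogen-bond donor and acceptor counts are 0, yet the step does not exceed the scatter. Nothing available explains this result.

This single swap changes the oxygen, the fluorine and the substitution place together, so their contributions remain inseparable. As far as these compounds go, whether plain phenyl, 2-fluorophenyl or an aminophenyl group here would give a step beyond the scatter remains open.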